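Series Notes: Aryl Substituent Swap Toward Compound 3

The compounds below may be only part of what the source reports. "The series", "measured", "known", "first", "only" and "open" are said of these compounds alone.

Compound 1 is `CCc1ccc2oc(CSc3nnc(CNc4ccccc4)n3CC)nc2c1`. In an assay on isolated protein for inhibition of long-chain fatty acid transport protein 1 (Homo sapiens) (on this read-out lower numbers stand for stronger inhibition and higher numbers for weaker inhibition), compound 1 gives > 1000 nM, which is a limit of the assay and not a number. Among the compounds with values here, the only numeric value in the set belongs to compound 2, `CCC(=O)c1ccc2oc(CS(=O)(=O)c3nnc(CNc4ccccc4)n3CC)nc2c1`, which in this assay gives 1670 nM; compound 2 differs from compound 1 in more than one place, so the two values show only that both compounds sit at the weak end of the read-out. For compound 1 the standing is fixed by the limit of > 1000 nM in this assay, at which 1 of the 2 values shown sits, so only a range can be given for it.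

Compound 3 is `CCn1c(CNc2ccccc2)nnc1SCc1nc2cc(OC(F)(F)F)ccc2o1`. It differs from compound 1 by trifluoromethoxy in place of ethyl on an aromatic carbon. Within the data shown here, no measured pair in the set isolates this change, so there is no measured step to rest on. The expected step that the limit leaves unreadable from compound 1 to compound 3 in this assay is none beyond the usual scatter, with compound 3 staying in the weak region where compound 1 sits. Compound 3 is accordingly estimated at 2000 nM, with a range from 600 nM to 8000 nM, and a considerable chance that only a limit is again reported.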

Compound 3, half-maximal inhibitory concentration: 100 nM
Compound 3: the middle estimate sits 20-fold (1.30 log units) above what was measured; the measured number lies below the stated range.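

Trifluoromethoxy in place of ethyl on this aromatic carbon gives an at least 10-fold lower number from compound 1 to compound 3 (1.00 log units; beyond the scatter) in this assay, and no other comparison in the set isolates a single change. With the rest of compound 1 held fixed, this one swap on the six-membered aromatic ring of carbon only is enough to move the read-out beyond the scatter, so the weak read-out of compound 1 does not hold for every compound sharing the rest of its structure. For compound 1 the value > 1000 nM is a limit of the assay and not a number, so the step gives a lower bound and not an exact size for the change: the limit of > 1000 nM in this assay, at which 1 of the 3 values shown sits.

The swap changes the oxygen, the fluorines and the heavy-atom count together, so this single pair cannot show which of them carries the step; methoxy, trifluoromethyl or a lone chlorine on the same aromatic carbon would separate these parts of the group. Also open, as far as these compounds go, is whether the step holds when other parts of compound 3 change, for instance with a carboxylic acid on the phenyl ring or a longer chain in place of the ethyl on the ring nitrogen.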